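A few compounds are considered here, and "the series" means these few. Any claim that something is new, unique, unknown or untested is made for them only; others in the source may bear on it.

In a functional assay on K-562R cells (Homo sapiens) for cytotoxicity, read by XTT assay, with a stated time of 24 h (a lower number here means a stronger inhibitor, a higher number a weaker inhibitor), compound 1 (`Cc1ccc(NC(=O)c2ccccc2OCCCCn2ccnc2)cc1Nc1nccc(-c2cccnc2)n1`) gives 83400 nM and compound 2 (`Cc1ccc(NC(=O)c2cc(I)ccc2OCCCCn2ccnc2)cc1Nc1nccc(-c2cccnc2)n1`) gives 81700 nM, so the two stand level within the scatter. Compound 3 (`Cc1ccc(OCCCCn2ccnc2)c(C(=O)Nc2ccc(C)c(Nc3nccc(-c4cccnc4)n3)c2)c1`) follows from compound 2 with methyl in place of iodo on an aromatic carbon. Among the measured compounds shown here, the only measured step at this carbon, a 1.0-fold lower number from compound 1 to compound 2 (0.01 log units; within the scatter), is iodo in place of hydrogen and stays within the scatter, so no step beyond the scatter is expected in this assay. The expected step is a 1.0-fold lower number from compound 2 to compound 3 (0.01 log units; within the scatter). Compound 3 is estimated at 80000 nM, with an expected range of 50000 nM to 125000 nM.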

Compound 3, half-maximal inhibitory concentration: 48600 nM
Compound 3: the middle estimate sits 1.6-fold (0.22 log units) above what was measured; measured number outside the range, below it.
By their numbers in this assay, from the lowest: compounds 3, 2 and 1 (each within the scatter of the next).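

In this assay this carbon, para to a 4-(1H-imidazol-1-yl)butoxy group, now carries hydrogen, iodo and methyl: methyl in place of iodo gives a 1.7-fold lower number from compound 2 to compound 3 (0.23 log units; within the scatter) and methyl in place of hydrogen gives a 1.7-fold lower number from compound 1 to compound 3 (0.23 log units; within the scatter) and both steps stay within the scatter. The earlier pair covered only iodo against hydrogen, and a carbon substituent here likewise produces no step beyond the scatter. Nothing on hand bears on a cause for these steps. From the compounds shown here alone, whether an amine, a carboxylic acid or an ethyl group at this carbon would move the number beyond the scatter stays open. Also open, going by these compounds, is whether this carbon stays as flat with a longer chain in place of the 4-(1H-imidazol-1-yl)butoxy group.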